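Working notes: hydrogen in place of methoxy

A few compounds are considered here, and "the series" means these few. Any claim that something is new, unique, unknown or untested is made for them only; others in the source may bear on it.

Measured in an in vitro ADME assay on microsomes from liver (Homo sapiens) for metabolic stability, tested at 0.2 uM (on this read-out lower numbers stand for slow clearance and higher numbers for fast clearance), so far:
- compound 1 `COC(C)(C)CCOc1cccc(OCc2[nH]c3ccccc3c(=O)c2C)c1` gives > 1000 mL/min/kg (a limit of the assay)
- compound 2 `O=c1c(Cl)c(COc2cccc(OCC3CCOCC3)c2)[nH]c2ccccc12` gives 460 mL/min/kg
- compound 3 `COc1ccc2[nH]c(COc3cccc(OCC4CCOCC4)c3)c(C)c(=O)c2c1` gives "not determined" (no result reported)

On these data alone, compound 3 has no number, so its place in this assay stays open. Within the data shown here, the entry for compound 1 is a limit, which leaves compound 2 as the only exact value. The step to compound 4 `Cc1c(COc2cccc(OCC3CCOCC3)c2)[nH]c2ccccc2c1=O` is hydrogen in place of methoxy on an aromatic carbon with hydrogen in place of methoxy on an aromatic carbon. Among the measured compounds shown here, with no measured step and no starting value from compound 3, no change beyond the usual scatter is expected in this assay, in either direction. The expectation therefore leans on compound 2 at 460 mL/min/kg as the one exact reference. The estimated value for compound 4 is 450 mL/min/kg with an expected range of 180 mL/min/kg to 1000 mL/min/kg in this read-out.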

Compound 4, clearance: 214 mL/min/kg
Compound 4: middle estimate off by 2.1-fold (0.32 log units), on the high side; the range from low to high includes it.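

In this assay, among these compounds, methyl in place of chloro on an aromatic carbon gives a 2.1-fold lower number from compound 2 to compound 4 (0.33 log units; beyond the scatter), the first step between two exact values. Oxan-4-yl in place of 2-methoxy-2-methylpropyl on a saturated chain carbon gives an at least 4.6-fold lower number from compound 1 to compound 4 (0.66 log units; beyond the scatter). That step starts from compound 1, whose entry is a limit and not a number: the limit of > 1000 mL/min/kg in this assay, at which 1 of the 4 values shown sits.

With no result for compound 3, the change from methoxy to hydrogen cannot be read. On these data alone, how a nitrile or an amine in place of the methyl of compound 4 would read in this assay stays open.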